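This account rests on a few compounds, and the source may have more. Where it says the series, first, only, none or still open, it means among the compounds named here.

Compound 1 `O=C(Nc1cc(Sc2ncnc3nc[nH]c23)c(O)c2ccccc12)c1ccc(Cl)cc1` is the starting point. In an assay on isolated protein for inhibition of RAC-alpha serine/threonine-protein kinase (Homo sapiens), read by fluorescence, with a stated time of 30 min, tested at 10 uM (a lower number here means less inhibition, a higher number more inhibition at the concentration tested (going by the name of the read-out)), compound 1 gives 21.7%, which places it second highest among the three compounds measured. Its nearest neighbour on the numbers is compound 2 `COc1ccc(/C=C/C(=O)Nc2cc(Sc3ncn[nH]3)c(O)c3ccccc23)cc1OC`, which in this assay gives 31.7%, a gap that lies within the usual scatter. Furthest from it is compound 3 `O=C(Nc1cc(Sc2nncs2)c(O)c2ccccc12)c1ccc(Cl)cc1`, which in this assay gives 7.5%; the change from compound 1 to compound 3 is a number 14.2 percentage points lower from compound 1 to compound 3 (beyond the scatter).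

Compound 4 `O=C(Nc1cc(Sc2ncn[nH]2)c(O)c2ccccc12)c1ccc(Cl)cc1` differs from compound 1 in one place: a group of 5 heavy atoms (2 carbon, 3 nitrogen; one five-membered aromatic ring with 3 hetero atoms) in place of a group of 9 heavy atoms (5 carbon, 4 nitrogen; one five-membered aromatic ring with 2 hetero atoms, one six-membered aromatic ring with 2 hetero atoms), on a sulfur. Going by the values given here, the only measured step that bears on this change is the one from compound 1 to compound 3, where a five-membered aromatic ring with three hetero atoms likewise stood in for the larger two-ring group on the sulfur and the number fell by a number 14.2 percentage points lower from compound 1 to compound 3 (beyond the scatter). Among the compounds with values here, compound 2 carries the same entering ring as compound 4 but a different amide, so the value that compound 2 gives, 31.7%, shows only that the entering ring can sit with a number of that size; no step to it is available. Within the data shown here, on the strength of the one comparable step, a fall beyond the scatter is expected in this assay for compound 4, estimated as a number 10.7 percentage points lower from compound 1 to compound 4 (beyond the scatter). Compound 4 is therefore estimated to give 11% in this assay, expected to lie between 0% and 24%.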

Compound 4, a percentage reported as inhibition, at one concentration (the size of the read-out at that concentration, not a potency): 50.1%
Compound 4: middle estimate off by 39.1 percentage points, on the low side; measured number above the stated range.
By their numbers in this assay, from the lowest: compound 3; then compounds 1 and 2 (each within the scatter of the next); then compound 4.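

In this assay, 1H-1,2,4-triazol-5-yl in place of the two-ring group on the sulfur gives a number 28.4 percentage points higher from compound 1 to compound 4 (beyond the scatter), so a five-membered aromatic ring with three hetero atoms at this place does not in itself lower the number, as compound 3 alone had suggested. Which such ring stands there matters a great deal: with the rest of the molecule unchanged, 1H-1,2,4-triazol-5-yl in place of 1,3,4-thiadiazol-2-yl gives a number 42.6 percentage points higher from compound 3 to compound 4 (beyond the scatter), a step larger than the one from the two-ring group. Nothing available accounts for this gap between the two five-membered rings.

From the compounds shown here alone, it remains open whether the result holds with other amides, since compound 2 carries the same ring on its sulfur with a different amide and gives 31.7%, and the values shown are single readings at one concentration rather than potencies. Going by these compounds, it is also open how other groups on this sulfur would read in this assay, such as a tetrazole ring, an imidazole ring or a short chain ending in a carboxylic acid.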